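A methoxy group on the fused ring of compound 2

This account rests on a few compounds, and the source may have more. Where it says the series, first, only, none or still open, it means among the compounds named here.

Of the compounds shown here, three from one series have been tested in an ADME assay on MCF-10A cells (Homo sapiens) for cytotoxicity, read by MTT assay, with a stated time of 72 h; a higher number here means a weaker inhibitor, a lower number a stronger inhibitor. Compound 1 `Cc1ccc(-c2ccc([N+](=O)[O-])cc2)n1-c1ccc(-c2nc3ccccc3s2)cc1` gives 38800 nM. Compound 2 `COc1cc(-c2ccc(C)n2-c2ccc(-c3nc4ccccc4s3)cc2)cc(OC)c1OC` gives 38800 nM, level with compound 1 at the digits shown, and together these two are the highest of the three numbers. Compound 3 `COc1ccc2nc(-c3ccc(-n4c(C)ccc4-c4ccc([N+](=O)[O-])cc4)cc3)sc2c1` gives 34900 nM, the nearest neighbour lying within the usual scatter of compound 2.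

Compound 4 `COc1ccc2nc(-c3ccc(-n4c(C)ccc4-c4cc(OC)c(OC)c(OC)c4)cc3)sc2c1` has not yet been measured in this assay. It differs from compound 2 in one place: methoxy in place of hydrogen on an aromatic carbon. Put another way, the 1,3-benzothiazol-2-yl part becomes a 6-methoxy-1,3-benzothiazol-2-yl part.

For the measured compounds named here, one measured step bears directly on this change. The same methoxy group added in the same place on the fused ring takes the number from compound 1 to compound 3, and that step is a 1.1-fold lower number from compound 1 to compound 3 (0.05 log units; within the scatter). It stays within the scatter, so the earlier example gives no sign of a real shift in this assay.

On that basis compound 4 is expected to sit at about 36000 nM, with a likely range from 18000 nM to 72000 nM. The expected step from compound 2 to compound 4 is therefore a 1.1-fold lower number from compound 2 to compound 4 (0.03 log units; within the scatter), which is no change beyond the scatter.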

Compound 4, half-maximal inhibitory concentration: 37800 nM
Estimate against measurement, compound 4: 1.1-fold (0.02 log units) below, and the stated range covers the measured number.
By their numbers in this assay, from the lowest: compounds 3, 4, 1 and 2 (each within the scatter of the next).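

Putting methoxy in place of hydrogen on the fused ring, which turns the 1,3-benzothiazol-2-yl part into a 6-methoxy-1,3-benzothiazol-2-yl part, produces no shift beyond the scatter in this assay on a second core, with a 1.0-fold lower number from compound 2 to compound 4 (0.01 log units; within the scatter). For the compounds shown here, until this result, the change had been read on the core of compound 1 alone, so a single small step could have been specific to that core. The two readings now agree closely, which means that this position tolerates the change in this assay on both cores shown, with no compound here going against that pattern: the same change on two cores in this assay, a 1.1-fold lower number (0.05 log units; within the scatter) from compound 1 to compound 3 and a 1.0-fold lower number (0.01 log units; within the scatter) from compound 2 to compound 4, 1.1-fold (0.03 log units) apart, within the scatter of two such steps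

Only hydrogen and methoxy appear at this place in the compounds shown, so it remains open whether a larger or different group there, such as an amine, a carboxylic acid or a longer chain like butoxy, would move the number beyond the scatter. All four numbers also come from this assay, so they leave open whether the methoxy group would make as little difference in any other test.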